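A few compounds are considered here, and "the series" means these few. Any claim that something is new, unique, unknown or untested is made for them only; others in the source may bear on it.

Notes on the series. Compound 1 `N#CC1=C(N)Oc2c(c3nc4ccccc4nc3c3ccccc23)C12C(=O)N(Cc1cnnn1-c1cccc(Cl)c1)c1ccccc12` gives 43600 nM in a functional assay on MCF7 cells (Homo sapiens) for antiproliferative activity, read by MTT assay, with a stated time of 48 h; on this read-out higher numbers stand for weaker inhibition and lower numbers for stronger inhibition. Compound 2 `N#CC1=C(N)Oc2c(c3nc4ccccc4nc3c3ccccc23)C12C(=O)N(Cc1cnnn1-c1ccc([N+](=O)[O-])cc1)c1ccccc12` returns only a limit of the assay in this assay, > 50000 nM. Compound 3 `Cc1ccc(Cl)cc1-n1nncc1CN1C(=O)C2(C(C#N)=C(N)Oc3c2c2nc4ccccc4nc2c2ccccc32)c2ccccc21` likewise returns only a limit in this assay, > 50000 nM, so nothing more than a lower bound is known for it. Among the compounds with values here, two of the three values so far sit at that limit (the limit of > 50000 nM in this assay, at which 2 of the 3 values shown sit).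

The measured steps read as follows: an at least 1.1-fold higher number from compound 1 to compound 2 (0.05 log units; that floor lies within the scatter) with a 4-nitrophenyl in place of a 3-chlorophenyl on the aromatic nitrogen; an at least 1.1-fold higher number from compound 1 to compound 3 (0.05 log units; that floor lies within the scatter) with a methyl in place of hydrogen on an aromatic carbon; and a step that the two limits leave unreadable from compound 2 to compound 3, which the two limits leave without a readable size.

Compound 4 `N#CC1=C(N)Oc2c(c3nc4ccccc4nc3c3ccccc23)C12C(=O)N(Cc1cnnn1-c1cc(Cl)ccc1Cl)c1ccccc12` differs from compound 3 by chloro in place of methyl on an aromatic carbon, on an aromatic carbon of a six-membered aromatic ring of carbon only, ortho to a large group and para to a chloro group. Within the data shown here, no measured step in this set swaps chloro for methyl, so no direct guide exists; the steps around compound 3 all run toward or sit at the limit. Compound 4 is therefore expected to stay near the limit, with a step of a number no higher from compound 3 to compound 4 (the limit leaves the size open) that is not readable beyond the scatter, and its value is estimated at 50000 nM within 20000 nM to 120000 nM.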

Compound 4, half-maximal inhibitory concentration: > 50000 nM
Compound 4: no number, only a limit; the forecaster's own chance of this, stated with the estimate: 60%; the middle value sits exactly at the limit.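

In this assay compound 4 returns only a limit of the assay, > 50000 nM. Chloro in place of hydrogen on this aromatic carbon, ortho to a large group and para to a chloro group, gives an at least 1.1-fold higher number from compound 1 to compound 4 (0.05 log units; that floor lies within the scatter), so a second chloro on the phenyl ring of compound 1 is now seen to leave a value that can only be bounded, as methyl at the same place does in compound 3. The steps that link compound 4 to compound 2 and compound 3 cannot be read, and the limit now holds most of the series: the limit of > 50000 nM in this assay, at which 3 of the 4 values shown sit.

As far as these compounds go, whether chloro and methyl at this place differ at all remains open, as does how far compound 4 and compound 3 lie beyond the limit. Also open, from the compounds shown here alone, is whether fluoro, an amine or a carboxylic acid at this place on the phenyl ring would give a value that can be read as a number in this assay.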